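Replacing bromo with cyano on compound 3

This account rests on a few compounds, and the source may have more. Where it says the series, first, only, none or still open, it means among the compounds named here.

In an ADME assay on MT4 cells (Homo sapiens) for cytotoxicity, read by MTT assay, with a stated time of 5 days (a lower number here means that less compound is tolerated, a higher number that more compound is tolerated), compound 1 (`N#Cc1ccc(Nc2nccc(OCC(=O)Nc3cccc(Cl)c3)n2)cc1`) gives only a limit of the assay, > 329000 nM. Compound 2 (`Cc1cc(OCC(=O)Nc2ccc(Cl)cc2)nc(Nc2ccc(C#N)cc2)n1`) gives 2630 nM, and compound 3 (`Cc1cc(OCC(=O)Nc2ccc(Br)cc2)nc(Nc2ccc(C#N)cc2)n1`) gives 930 nM, the lower of the two actual numbers. Compound 4 (`Cc1cc(OCC(=O)Nc2ccc(C#N)cc2)nc(Nc2ccc(C#N)cc2)n1`) has cyano in place of bromo on an aromatic carbon, para to a large group: cyano in place of bromo on an aromatic carbon. Among the measured compounds shown here, one measured step bears on this change, the modest 2.8-fold lower number from compound 2 to compound 3 (0.45 log units; beyond the scatter), and no measured compound tests this exact exchange. In this assay, a similarly modest move toward a higher number is therefore expected, with considerable uncertainty. The expected step is a 2.7-fold higher number from compound 3 to compound 4 (0.43 log units; beyond the scatter). Compound 4 is estimated at 2500 nM, with an expected range of 700 nM to 12000 nM.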

Compound 4, half-maximal cytotoxic concentration: > 325000 nM
Compound 4 ended at the assay's limit (the forecaster's own chance of this, stated with the estimate: 5%); middle value at least 130-fold (2.11 log units) from the limit.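

In this assay cyano on this aromatic carbon, para to a large group, gives an at least 340-fold higher number from compound 3 to compound 4 (2.54 log units; beyond the scatter) and an at least 120-fold higher number from compound 2 to compound 4 (2.09 log units; beyond the scatter) where the exchange of one halogen for the other had moved the number only modestly. Compound 4 gives only a limit of the assay, so both steps are lower bounds: the limit of > 325000 nM in this assay, at which 1 of the 4 values shown sits. The compounds shown leave open how far the number of compound 4 lies past that limit. They also leave open whether an amine or a carboxylic acid at this place would give a step of similar size.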